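This account rests on a few compounds, and the source may have more. Where it says the series, first, only, none or still open, it means among the compounds named here.

Measured so far:
compound 1, `N#Cc1ccc(NC(=O)c2cc(-c3ccncc3)ccc2O)cc1` — 5410 nM
compound 2, `O=C(Nc1ccc(C(F)(F)F)cc1)c1cc(Br)c(F)cc1O` — 450 nM

In a functional assay on HL-60 cells (Homo sapiens) for cytotoxicity, read by luminescence and CellTiter-Glo, with a stated time of 3 days (on this read-out higher numbers stand for weaker inhibition and lower numbers for stronger inhibition), compound 1 gives 5410 nM, the highest of the two numbers measured, while compound 2 gives 450 nM, a lower number that lies beyond the usual scatter of the two values. The two compounds differ in several places at once, so the numbers alone do not tell which change matters.

Compound 3, `N#Cc1ccc(NC(=O)c2cc(Br)ccc2O)cc1`, has not yet been tested in this assay. It differs from compound 1 in one place: bromo in place of pyridin-4-yl on an aromatic carbon. The bromo group that enters sits on an aromatic carbon of the core, para to a hydroxy group, the same kind of position where compound 2 also carries a bromo group.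

For compound 3 a moderate step downward from compound 1 is expected, a 2.5-fold lower number from compound 1 to compound 3 (0.39 log units; beyond the scatter), likely near the edge of the scatter. The estimate for compound 3 in this assay is 2200 nM, with a range from 500 nM to 8000 nM.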

Compound 3, half-maximal inhibitory concentration: 620 nM
Compound 3: the middle estimate sits 3.5-fold (0.55 log units) above what was measured; the measured number falls inside the stated range.
By their numbers in this assay, from the lowest: compounds 2 and 3 (each within the scatter of the next); then compound 1.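

In this assay, among the compounds shown here, putting bromo in place of pyridin-4-yl on the aromatic carbon para to the hydroxy group gives an 8.7-fold lower number from compound 1 to compound 3 (0.94 log units; beyond the scatter), a step that could not be read from the earlier compounds, which differ in several places at once. At this position, then, the six-membered aromatic ring with its nitrogen is not needed to reach the lower number: a single bromine atom, counted with no hydrogen-bond acceptor, gives a lower number than the ring does. Nothing available here explains why the number falls.

As far as these compounds go, whether this step belongs to bromine in particular remains open, since a chlorine atom, a methyl group or an amine on the same carbon would show how much depends on the group chosen. From the compounds shown here alone, it is also open whether the step would persist if the nitrile of compound 3 were replaced by a carboxylic acid.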